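The source may report more compounds than this note shows. Statements on the series, on what has been measured and on what is new or still open speak of the compounds shown alone.

Measured in an ADME assay on cells (Homo sapiens) for cytotoxicity, read by resazurin assay, with a stated time of 5 days; a higher number here means that more compound is tolerated, a lower number that less compound is tolerated:

- compound 1 `COc1ccc(-c2nc(COc3cccc(Cl)c3)nc3ccsc23)cn1`: > 50000 nM
- compound 2 `COc1ccc(-c2nc(CSc3ccc(C(F)(F)F)cn3)nc3ccsc23)cn1`: > 50000 nM

Compound 1 stands at > 50000 nM, which is a limit of the assay and not a number. Compound 2 stands at > 50000 nM, which is likewise a limit. The record so far is therefore (the limit of > 50000 nM in this assay, at which 2 of the 2 values shown sit), and no step can be read from it.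

Compound 3 `COc1ccc(-c2nc(CSc3cc(C)cc(C)c3)nc3ccsc23)cn1` has not yet been measured. The change from compound 1 is (3,5-dimethylphenyl)sulfanyl in place of 3-chlorophenoxy on a saturated chain carbon bound to an aromatic carbon. In words, (3,5-dimethylphenyl)sulfanyl stands in place of 3-chlorophenoxy on a saturated chain carbon bound to an aromatic carbon.

Going by the values given here, no measured step shows what such a change does in this assay, so the expectation rests on the two limits alone. No shift beyond the usual scatter is expected, and another limit would be no surprise. The estimated change, an at least 1.1-fold lower number from compound 1 to compound 3 (0.04 log units; that floor lies within the scatter), is expected to stay within that scatter. For compound 3 the expected half-maximal cytotoxic concentration is 45000 nM, with an estimated range from 20000 nM to 50000 nM.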

Compound 3, half-maximal cytotoxic concentration: > 50000 nM
Compound 3: only a limit was reported (the forecaster's own chance of this, stated with the estimate: 70%); at least 1.1-fold (0.04 log units) between middle value and limit.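

In this assay compound 3 gives > 50000 nM, which is a limit of the assay and not a number. Compound 1 and compound 3 both stand at such a limit, so no step between them can be read: the limit of > 50000 nM in this assay, at which 3 of the 3 values shown sit.

The compounds shown leave open what half-maximal cytotoxic concentration, if any, each of them would reach in this assay.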